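Chloro for Hydrogen: Expected Tolerance of Compound 4

The source may report more compounds than this note shows. Statements on the series, on what has been measured and on what is new or still open speak of the compounds shown alone.

Compound 1 `O=c1[nH]cc(S(=O)(=O)Nc2ccccc2-c2cn(-c3ccccc3)nn2)c(=O)[nH]1` – in an ADME assay on GES1 cells (Homo sapiens) for cytotoxicity, read by MTT assay, with a stated time of 24 h (a higher number here means that more compound is tolerated, a lower number that less compound is tolerated), compound 1 gives > 100000 nM, which is a limit of the assay, not a number.
Compound 2 `Cc1cccc(-n2cc(-c3cccc(NS(=O)(=O)c4c[nH]c(=O)[nH]c4=O)c3)nn2)c1` – in this assay compound 2 gives 18500 nM.
Compound 3 `O=c1[nH]cc(S(=O)(=O)Nc2ccc(-c3cn(-c4ccccc4)nn3)cc2)c(=O)[nH]1` – in this assay compound 3 gives "not toxic" (no number reported).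

Of the three measured compounds, only compound 2 is reported with a single number. Compound 1 sits at the limit of > 100000 nM in this assay, at which 1 of the 3 values shown sits. For the measured compounds named here, compound 3 has no single number at all; it is described only as not toxic, so it stands at the tolerated end of the set alongside compound 1, while compound 2 is the one compound for which a finite concentration was reached. Going by the values given here, no step between two measured compounds that differ in a single place is available here.

Compound 4 `O=c1[nH]cc(S(=O)(=O)Nc2ccc(-c3cn(-c4ccc(Cl)cc4)nn3)cc2)c(=O)[nH]1` differs from compound 3 by chloro in place of hydrogen on an aromatic carbon. Without a measured step of this kind to lean on, the expectation is a small lowering of the tolerated concentration, possibly none beyond the usual scatter. Compound 4 is therefore estimated at 50000 nM, within a range from 12000 nM to 200000 nM.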

Compound 4, half-maximal cytotoxic concentration: 23300 nM
Compound 4: the middle estimate sits 2.1-fold (0.33 log units) above what was measured; measured number inside the range.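

In this assay compound 3 is reported as "not toxic" (no number reported) and compound 4 gives 23300 nM as its value, so no step between them can be read, and nothing shown bears on this result. The compounds shown leave open how chloro in place of hydrogen changes the tolerated concentration.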